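Trading one side ring for another at the carbonyl

The source may hold more compounds than are shown below. What is called first, only, known or untested is meant among the compounds shown, and "the series" means these compounds.

Of the compounds shown here, three sharing one core have been tested in a functional assay (aorta) with Rattus norvegicus as the target (a lower number here means that less compound is needed, a higher number that more compound is needed for the effect), so far. Compound 1 (`COc1ccc(-c2nc(C(=O)N(C)C)sc2-c2ccc(OC)cc2)cc1`) gives 3 uM there, and compound 3 (`COc1ccc(-c2nc(C(=O)N3CCCCC3CCO)sc2-c2ccc(OC)cc2)cc1`) gives 6.8 uM as the higher of the two numbers. Compound 2 (`COc1ccc(-c2nc(C(=O)N=C(N)N)sc2-c2ccc(OC)cc2)cc1`) reads > 100 uM as a limit and not a number.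

Compound 4 (`COc1ccc(-c2nc(C(=O)N3CCNC(CCO)C3)sc2-c2ccc(OC)cc2)cc1`) is still unmeasured. It carries 3-(2-hydroxyethyl)piperazin-1-yl in place of 2-(2-hydroxyethyl)piperidin-1-yl on the carbonyl carbon (3-(2-hydroxyethyl)piperazin-1-yl in place of 2-(2-hydroxyethyl)piperidin-1-yl on a carbonyl carbon).

Two measured changes at this carbonyl carbon bear on it. One was modest, with a 2.3-fold higher number from compound 1 to compound 3 (0.36 log units; beyond the scatter) after dimethylamino gave way to the ring group. The other was large, with an at least 33-fold higher number from compound 1 to compound 2 (1.52 log units; beyond the scatter) after a group without a ring came in. Compound 4 keeps the six-membered non-aromatic ring and the hydroxyethyl chain of compound 3 at 6.8 uM in its value, so the modest step is the closer guide. The expected change is a 1.3-fold higher number from compound 3 to compound 4 (0.12 log units; within the scatter) and stays within the scatter. For compound 4 the estimated value is 9 uM with an expected range from 2.5 uM to 50 uM in this assay overall.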

Compound 4, concentration for half-maximal effect: 9.5 uM
Compound 4: middle estimate off by 1.1-fold (0.02 log units), on the low side, and the stated range covers the measured number.
By their numbers in this assay, from the lowest: compound 1; then compounds 3 and 4 (each within the scatter of the next). At a limit, above all of these: compound 2.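

In this assay, 3-(2-hydroxyethyl)piperazin-1-yl in place of 2-(2-hydroxyethyl)piperidin-1-yl on the carbonyl carbon gives a 1.4-fold higher number from compound 3 to compound 4 (0.15 log units; within the scatter), so these two ring groups cannot be told apart at this position. The new ring group also gives a 3.2-fold higher number from compound 1 to compound 4 (0.50 log units; beyond the scatter) and an at least 10-fold lower number from compound 2 to compound 4 (1.02 log units; beyond the scatter), so compound 4, like compound 3, sits much nearer to the dimethylamino compound than to the compound without a ring. Compound 2 stands at a limit and not a number: the limit of > 100 uM in this assay, at which 1 of the 4 values shown sits.

As far as these compounds go, it remains open whether a carboxylic acid or a longer chain in place of the hydroxyethyl chain would shift the number in this assay. Also open, from the compounds shown here alone, is whether plain piperidin-1-yl or morpholin-4-yl, without that chain, would stay this close to dimethylamino.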